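A ring oxygen at a flat read-out

This account rests on a few compounds, and the source may have more. Where it says the series, first, only, none or still open, it means among the compounds named here.

In a toxicity assay on HT-29 cells (Homo sapiens) for cytotoxicity (on this read-out lower numbers stand for higher toxicity in this test and higher numbers for lower toxicity in this test), compound 1 `CCCCn1nc(C(=O)N[C@H]2COc3ccccc3N(C)C2=S)nc1Cc1ccccc1` gives > 100000 nM, which is a limit and not a number. Compound 2 `CN1C(=S)[C@@H](NC(=O)c2nc(Cc3ccccc3)n(C3CCCC3)n2)COc2ccccc21` gives > 100000 nM, also a limit, so only a bound is known for where it stands. Going by the values given here, the sole measured step is a step that the two limits leave unreadable from compound 1 to compound 2, with cyclopentyl in place of butyl on an aromatic nitrogen. Among the compounds with values here, the record for the series so far is the limit of > 100000 nM in this assay, at which 2 of the 2 values shown sit.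

Compound 3 `CN1C(=S)[C@@H](NC(=O)c2nc(Cc3ccccc3)n(C3CCOC3)n2)COc2ccccc21` changes that same substituent again: oxolan-3-yl in place of cyclopentyl on an aromatic nitrogen. The step that the two limits leave unreadable from compound 1 to compound 2 gives no size to carry over, so no direction can be expected, and no shift beyond the scatter is anticipated in this assay because of the limit of > 100000 nM in this assay, at which 2 of the 2 values shown sit. The expected step is a step that the limit leaves unreadable from compound 2 to compound 3. For compound 3 the estimate is 120000 nM, with an expected range from 60000 nM to 300000 nM.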

Compound 3, half-maximal cytotoxic concentration: > 100000 nM
Compound 3 gave a limit, no number (the forecaster's own chance of this, stated with the estimate: 90%); the middle value is on the limit's open side.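

Compound 3 also gives a limit and not a number in this assay, so no step among compound 1, compound 2 and compound 3 can be read: the limit of > 100000 nM in this assay, at which 3 of the 3 values shown sit.

The compounds shown leave open whether butyl, cyclopentyl or oxolan-3-yl on the aromatic nitrogen makes any difference in this assay.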